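Compound 3 to compound 4: one nitrogen for a sulfur ring

A few compounds are considered here, and "the series" means these few. Any claim that something is new, unique, unknown or untested is made for them only; others in the source may bear on it.

Of the compounds shown here, three sharing one core have been read so far. Among the compounds with values here, in a functional assay on RAW264.7 cells (Mus musculus) for inhibition, read by Griess assay, with stated times of 3 h and 24 h (a lower number here means a stronger inhibitor, a higher number a weaker inhibitor), compound 1 (`C=C1CC[C@H]2[C@@](C)(CC[C@@H](OC(=O)c3ccccc3)[C@@]2(C)NC=O)[C@@H]1/C=C/C1=CCOC1=O`) gives 50000 nM, the only actual number among them. Compound 2 (`C=C1CC[C@H]2[C@@](C)(CC[C@@H](OC(=O)c3ccc([N+](=O)[O-])cc3)[C@@]2(C)NC=O)[C@@H]1/C=C/C1=CCOC1=O`) gives > 50000 nM, which is a limit of the assay. Compound 3 (`C=C1CC[C@H]2[C@@](C)(CC[C@@H](OC(=O)CCCC[C@@H]3CCSS3)[C@@]2(C)NC=O)[C@@H]1/C=C/C1=CCOC1=O`) gives > 50000 nM, which is also a limit. Compound 3 therefore stands at the limit of > 50000 nM in this assay, at which 2 of the 3 values shown sit.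

The next compound, compound 4 (`C=C1CC[C@H]2[C@@](C)(CC[C@@H](OC(=O)CN)[C@@]2(C)NC=O)[C@@H]1/C=C/C1=CCOC1=O`), differs from compound 3 by this change: one nitrogen atom in place of a group of 8 heavy atoms (6 carbon, 2 sulfur; one five-membered non-aromatic ring with 2 hetero atoms), on a saturated chain carbon bound to a carbonyl carbon.

Within the data shown here, three measured steps bear on this change, since each alters the same ester group. They are a number no lower from compound 1 to compound 2 (the limit leaves the size open), a number no lower from compound 1 to compound 3 (the limit leaves the size open) and a step that the two limits leave unreadable from compound 2 to compound 3. None of them has a readable size, and none shows a gain in inhibition. Among the measured compounds shown here, compound 1 at 50000 nM remains the only number, and no measured step runs to a lower one, so no large gain is expected for compound 4. The expected result in this assay is an at least 1.1-fold lower number from compound 3 to compound 4 (0.04 log units; that floor lies within the scatter), with the reading staying close to the limit and quite possibly reported only as a limit. The estimated value for compound 4 is 45000 nM, with an expected range of 12000 nM to 100000 nM.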

Compound 4, half-maximal inhibitory concentration: > 50000 nM
Compound 4 ended at the assay's limit; the forecaster's own chance of this, stated with the estimate: 60%; middle value at least 1.1-fold (0.04 log units) from the limit.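

In this assay compound 4 gives > 50000 nM, which is a limit of the assay and not a number. An amino group on this saturated chain carbon bound to a carbonyl carbon therefore brings no reading under the limit, any more than the much larger sulfur ring group it replaces, and the result is a number no lower from compound 1 to compound 4 (the limit leaves the size open), while the steps linking compound 4 to compound 2 and compound 3 cannot be read. The ester position has now carried phenyl, 4-nitrophenyl, a sulfur ring group on a chain and aminomethyl, and the readings still gather at one point: the limit of > 50000 nM in this assay, at which 3 of the 4 values shown sit.

From the compounds shown here alone, how compound 2, compound 3 and compound 4 rank against one another remains open, as does the size of their steps from compound 1. Going by these compounds, it is also open whether a carboxylic acid or a longer chain ending in an amine at this ester would give a measurable number in this assay.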